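Branching the side chain of an enyne ester

The source may hold more compounds than are shown below. What is called first, only, known or untested is meant among the compounds shown, and "the series" means these compounds.

Compound 2, `CCCC(C#CC(=O)OC)O/C=C/C(=O)OC`, bears a propyl group on the saturated chain carbon that also carries the ether oxygen and the triple-bonded carbon. In a functional assay on HBL-100 cells (Homo sapiens) for antiproliferative activity, read by sulforhodamine B assay, with a stated time of 48 h (on this read-out higher numbers stand for weaker inhibition of growth and lower numbers for stronger inhibition of growth), compound 2 gives 270 nM, the lower of the two numbers shown, though its nearest neighbour sits within the usual scatter. That neighbour is compound 1, `COC(=O)C#CC(O/C=C/C(=O)OC)C(C)c1ccccc1`, which carries a methyl and a phenyl on the same carbon; in this assay compound 1 gives 490 nM. Compound 3, `C#CCO/C=C/C(=O)OC`, has no substituent at all on that carbon, and in this assay compound 3 reaches only the limit > 100000 nM, so it is not a number but the edge of what the assay reports, as noted in the limit of > 100000 nM in this assay, at which 1 of the 3 values shown sits.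

Compound 4, `COC(=O)C#CC(O/C=C/C(=O)OC)C(C)C`, differs from compound 2 by a single rearrangement: isopropyl in place of propyl on a saturated chain carbon bound to an oxygen on an unsaturated carbon and a triple-bonded carbon. The only branched comparator, compound 1, is within the scatter of compound 2, so the step of a 1.2-fold higher number from compound 2 to compound 4 (0.07 log units; within the scatter) is expected to be small, with no clear direction beyond the scatter. Compound 4 is therefore estimated at 320 nM, most likely between 110 nM and 1000 nM.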

Compound 4, concentration for 50% growth inhibition: 450 nM
Estimate against measurement, compound 4: 1.4-fold (0.15 log units) below; the range from low to high includes it.
By their numbers in this assay, from the lowest: compounds 2, 4 and 1 (each within the scatter of the next). At a limit, above all of these: compound 3.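

In this assay, moving from a straight to a branched three-carbon group at this position gives a 1.7-fold higher number from compound 2 to compound 4 (0.22 log units; within the scatter), so this rearrangement of the same atoms produces no change that can be told from the scatter. Methyl in place of phenyl gives a 1.1-fold lower number from compound 1 to compound 4 (0.04 log units; within the scatter), which shows that a value in this range does not depend on the phenyl group of compound 1. Nothing measured here offers an explanation for either step.

Going by these compounds, whether a longer chain such as hexyl, or an amine, would fit at this position stays open. Compound 3 gives > 100000 nM, which is a limit and not a number, and it differs from the other compounds in more than one place, so it cannot show what the group on this carbon contributes alone.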